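This account rests on a few compounds, and the source may have more. Where it says the series, first, only, none or still open, it means among the compounds named here.

Measured in a functional assay on HepG2 cells (Homo sapiens) for inhibition, read by MTT assay, with a stated time of 48 h; on this read-out higher numbers stand for weaker inhibition and lower numbers for stronger inhibition:
- Compound 1 `COc1ccc(-c2nc3ccccn3c2Sc2ccccc2)cc1`: 54200 nM
- Compound 2 `C(=C/c1nc2ccccn2c1Sc1ccccc1)\c1ccccc1`: 8800 nM
- Compound 3 `Cc1ccc2nc(-c3ccc(Cl)cc3)c(Sc3ccccc3)n2c1`: 63100 nM

Compound 3 lies within the scatter of compound 1, and both stand well above compound 2, so both inhibit more weakly in this assay.

Compound 4 `Clc1ccc(-c2nc3ccccn3c2Sc2ccccc2)cc1` has not yet been measured. It differs from compound 3 by hydrogen in place of methyl on an aromatic carbon.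

Going by the values given here, the only measured step, a 6.2-fold lower number from compound 1 to compound 2 (0.79 log units; beyond the scatter), swaps 4-methoxyphenyl for 2-phenylethenyl elsewhere in the molecule, so it says nothing directly about removing this methyl. Compound 1, which also lacks the methyl, gives 54200 nM, which is some indication that numbers of this size are possible without it. No change beyond the scatter is therefore expected.

The estimated step is a 1.1-fold lower number from compound 3 to compound 4 (0.06 log units; within the scatter).

For compound 4 the expected value is 55000 nM, with an estimated range of 25000 nM to 120000 nM.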

Compound 4, half-maximal inhibitory concentration: 13900 nM
The estimate for compound 4 lay 4.0-fold (0.60 log units) above the measured number, outside the stated range (below it).
By their numbers in this assay, from the lowest: compounds 2 and 4 (each within the scatter of the next); then compounds 1 and 3 (each within the scatter of the next).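

In this assay, the methyl on the six-membered aromatic ring with 1 nitrogen is not a neutral passenger: replacing it with hydrogen gives a 4.5-fold lower number from compound 3 to compound 4 (0.66 log units; beyond the scatter), so this position can change the number even though the group there is a single carbon. With that methyl absent, the group on the other aromatic carbon also matters, as chloro in place of methoxy gives a 3.9-fold lower number from compound 1 to compound 4 (0.59 log units; beyond the scatter), whereas 4-chlorophenyl in place of 2-phenylethenyl gives a 1.6-fold higher number from compound 2 to compound 4 (0.20 log units; within the scatter), a step that leaves those two compounds indistinguishable. Nothing available here explains why these numbers move.

From the compounds shown here alone, the methyl step rests on one pair, so whether it holds with 4-methoxyphenyl or 2-phenylethenyl in the molecule remains open. Going by these compounds, what an amine, a carboxylic acid or a longer alkyl chain would do at this position also remains open.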